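Hydroxy for Amino on the Sugar Chain of Compound 2

This account rests on a few compounds, and the source may have more. Where it says the series, first, only, none or still open, it means among the compounds named here.

In a functional assay on P388 cells (Mus musculus) for antiproliferative activity, with a stated time of 72 h (a lower number here means that less compound is needed, a higher number that more compound is needed for the effect), the measured compounds stand as follows:
Compound 1, `Cc1cn([C@H]2C[C@H](CF)[C@@H](CO)O2)c(=O)[nH]c1=O`, gives > 100 uM, a limit of the assay.
Compound 2, `Cc1cn([C@@H]2O[C@H](CO)[C@@H](CN)[C@H]2O)c(=O)[nH]c1=O`, gives > 100 uM, a limit of the assay.
Compound 3, `Cc1cn([C@@H]2O[C@H](CO)[C@@H](CN)[C@@H]2O)c(=O)[nH]c1=O`, gives > 100 uM, a limit of the assay.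

Compound 2 thus sits at the limit of this assay, as do the other two compounds (the limit of > 100 uM in this assay, at which 3 of the 3 values shown sit). The step that the two limits leave unreadable from compound 2 to compound 3 is framed by two limits and its size cannot be read (the fact that compounds 2 and 3 differ only in the configuration as drawn). Compound 4, `Cc1cn([C@@H]2O[C@H](CO)[C@@H](CO)[C@H]2O)c(=O)[nH]c1=O`, differs from compound 2 by hydroxy in place of amino on a saturated chain carbon bound to a saturated ring carbon. For the measured compounds named here, no measured step concerns this change, and the measured steps give no direction. Compound 4 is therefore expected to remain near the limit, with the step that the limit leaves unreadable from compound 2 to compound 4 expected to stay within the scatter. For compound 4 an estimate of 200 uM, from 50 uM to 1000 uM, is given.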

Compound 4, concentration for half-maximal effect: > 100 uM
Compound 4: only a limit was reported (the forecaster's own chance of this, stated with the estimate: 85%); the middle value lies beyond the limit too.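

No step can be read from compound 2 to compound 4, because both compounds stand at a limit and not at a number: the limit of > 100 uM in this assay, at which 4 of the 4 values shown sit.

The compounds shown leave open whether hydroxy in place of amino changes anything in this assay at all.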